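Methoxy count on the aryl ring bearing the pyrazole

A few compounds are considered here, and "the series" means these few. Any claim that something is new, unique, unknown or untested is made for them only; others in the source may bear on it.

Measured so far in a functional assay on OVCAR-4 cells (Homo sapiens) for inhibition, read by sulforhodamine B assay, with a stated time of 48 h; a lower number here means that less compound is tolerated, a higher number that more compound is tolerated:
compound 1 `COc1ccc(-c2cc(/C=C/C(=O)c3ccc(N)cc3)[nH]n2)cc1`: 51200 nM
compound 2 `COc1cc(-c2cc(/C=C/C(=O)c3ccc(N)cc3)[nH]n2)cc(OC)c1OC`: 23700 nM
compound 3 `COc1cc(-c2cc(/C=C/C(=O)c3ccc(Cl)c(Cl)c3)[nH]n2)cc(OC)c1OC`: a limit of the assay, > 100000 nM

Compound 2 holds the lowest of the two numbers that are real values; compound 1 gives a higher number, and the gap between them is beyond the scatter. The value for compound 3 is a limit, not a number; this is the limit noted as the limit of > 100000 nM in this assay, at which 1 of the 3 values shown sits.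

Compound 4 `COc1ccc(-c2cc(/C=C/C(=O)c3ccc(N)cc3)[nH]n2)cc1OC` differs from compound 2 by a single change, (hydrogen in place of methoxy on an aromatic carbon). Among the measured compounds shown here, the only step measured so far on this series, an at least 4.2-fold higher number from compound 2 to compound 3 (0.62 log units; beyond the scatter), concerns the group on the carbonyl carbon and not the aryl ring that carries the pyrazole, so it does not bear on the change from compound 2 to compound 4. What does bear on it is the pair of values for compound 1 and compound 2: compound 1 carries a single methoxy group and gives the higher number, compound 2 carries three and gives the lower. Compound 4, with two methoxy groups, is therefore expected to fall between the two, with the step from compound 2 to compound 4 estimated as a 1.5-fold higher number from compound 2 to compound 4 (0.17 log units; within the scatter).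

The estimate for compound 4 in this assay is 35000 nM, with a range from 15000 nM to 80000 nM.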

Compound 4, concentration lethal to 50% of the cells: 40500 nM
For compound 4 the middle estimate is 1.2-fold (0.06 log units) below the measured one; low and high end bracket the measured number.
By their numbers in this assay, from the lowest: compounds 2, 4 and 1 (each within the scatter of the next, the first and the last beyond it). At a limit, above all of these: compound 3.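

In this assay, hydrogen in place of methoxy on an aromatic carbon, ortho to a methoxy group and meta to a large group, gives a 1.7-fold higher number from compound 2 to compound 4 (0.23 log units; within the scatter) and the matching single step from the other side, methoxy in place of hydrogen on an aromatic carbon, gives a 1.3-fold lower number from compound 1 to compound 4 (0.10 log units; within the scatter) in the same series. The gap between compound 1 and compound 2, which is beyond the scatter but spans two methoxy groups, therefore divides into two single steps, neither of which leaves the scatter on its own, so no one methoxy group on this ring can be singled out as carrying the gap. Nothing shown accounts for these steps.

On these data alone, whether a hydroxyl group, an amine or a longer chain such as ethoxy on this aromatic carbon would give a step beyond the scatter stays open. Also open is whether the methoxy steps read the same with 3,4-dichlorophenyl in place of 4-aminophenyl on the carbonyl carbon, as the compounds shown hold no such pair.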